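The compounds below may be only part of what the source reports. "The series", "measured", "known", "first", "only" and "open" are said of these compounds alone.

Among the measured compounds shown here, the read-out here is a functional assay on HCT-116 cells (Homo sapiens) for cytotoxicity, read by scintillation counting and thymidine incorporation, with a stated time of 72 h (on this read-out higher numbers stand for weaker inhibition and lower numbers for stronger inhibition), and the three compounds measured so far spread widely on it. Compound 1 `CCOc1cc(C(=CC#N)c2ccc(S(C)(=O)=O)cc2)ccc1OC` gives only a limit in this assay, > 10000 nM, so no number is known for it. For the measured compounds named here, it is the single compound among the three that sits at the limit of > 10000 nM in this assay, at which 1 of the 3 values shown sits. The other two give numbers. Compound 2 `C=C(c1ccc(OC)c(N)c1)c1ccc(OC)c(OCC)c1` gives 38 nM in this assay, and compound 3 `CC=C(c1cc(OC)cc(OC)c1)c1ccc(OC)c(O)c1` gives 30 nM; these two values lie within the usual scatter of each other, so no order between them can be claimed.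

Compound 4 `CCOc1cc(C(=CC#N)c2ccc(NC)cc2)ccc1OC` has not yet been measured. It differs from compound 1 in one place: methylamino in place of methylsulfonyl on an aromatic carbon. Going by the values given here, no two measured compounds differ from each other in exactly one place, so no measured step of this kind is available for comparison. What can be said is that compound 2, which also carries a nitrogen-bearing group and no methylsulfonyl, gives 38 nM, a number in the potent range.

On that basis compound 4 is expected to be stronger than compound 1, a step of an at least 10-fold lower number from compound 1 to compound 4 (1.00 log units; beyond the scatter) that should lie beyond the scatter. The expected value for compound 4 is 1000 nM, with a range from 100 nM to 10000 nM.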

Compound 4, half-maximal inhibitory concentration: 55 nM
Compound 4: the middle estimate sits 18-fold (1.26 log units) above what was measured, and the stated range ends above it.
By their numbers in this assay, from the lowest: compounds 3, 2 and 4 (each within the scatter of the next). At a limit, above all of these: compound 1.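

Replacing methylsulfonyl with methylamino on an aromatic carbon, para to a large group, while the rest of the core stays the same, brings an at least 180-fold lower number from compound 1 to compound 4 (2.25 log units; beyond the scatter) in this assay, so activity in these cells depends strongly on what this position carries. Among the compounds shown here, this is the first pair of measured compounds that differ in one place, and it isolates the effect of one group, which the earlier compounds, differing in several places at once, could not do. Compound 1 gives > 10000 nM, which is a limit and not a number, so the step has a known minimum but no known full size: the limit of > 10000 nM in this assay, at which 1 of the 4 values shown sits.

Two groups on one carbon cannot show which part of the change matters, since methylamino differs from methylsulfonyl in size and also brings a hydrogen-bond donor that methylsulfonyl lacks, and the compounds shown give no cause for the step. Other groups at the same position, such as a plain amine, a methoxy group or a longer chain like ethylamino, remain open, so it is unknown whether the nitrogen, the hydrogen on it or simply the loss of methylsulfonyl counts most.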